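The source may hold more compounds than are shown below. What is called first, only, known or untested is meant among the compounds shown, and "the series" means these compounds.

Working notes on the series. Compound 1 `CCC(C(=O)N1CCN(c2ccccc2Cl)CC1)N1C(=O)CCC1=O` stands highest of the two compounds measured in a functional assay on the whole organism (strain Swiss) with Mus musculus as the target, in the maximal electroshock model, with a stated time of 0.25 h, at a dose of 300 mg/kg by the intraperitoneal route (on this read-out lower numbers stand for a weaker effect and higher numbers for a stronger effect at the one dose given), where compound 1 gives 50%. Its nearest neighbour is compound 2 `CCC(C(=O)N1CCN(c2ccccc2C(F)(F)F)CC1)N1C(=O)CCC1=O`, which in this assay gives 25%; the change a number 25 percentage points lower from compound 1 to compound 2 (beyond the scatter) is a modest fall, beyond the scatter. Compound 3 `CCC(C(=O)N1CCN(c2cccc(Cl)c2)CC1)N1C(=O)CCC1=O` is not yet measured; it differs from compound 1 by 3-chlorophenyl in place of 2-chlorophenyl on an amine nitrogen in a ring. Within the data shown here, no measured step touches this change, which moves the chloro group rather than replacing it, so no step beyond the scatter is expected in this assay, the estimated change being a number 10 percentage points lower from compound 1 to compound 3 (within the scatter). For compound 3 the expected value is 40%, with a range from 15% to 70%.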

Compound 3, a percentage reported as activity, at one dose (the size of the read-out at that dose, not a potency): 75%
Estimate against measurement, compound 3: 35 percentage points below; measured number outside the range, above it.
By their numbers in this assay, from the lowest: compound 2; then compound 1; then compound 3.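

In this assay the exchange of 2-chlorophenyl for 3-chlorophenyl on the ring amine nitrogen gives a number 25 percentage points higher from compound 1 to compound 3 (beyond the scatter) and so shows that the read-out depends on where the chloro group stands, not only on which group is present. The earlier step replaced the group, whereas this one keeps the same atoms and still moves the number beyond the scatter. No available evidence bears on this rise. Open, from the compounds shown here alone, is whether trifluoromethyl responds to the same move as chloro, and how a methoxy group would read in place of the chloro group.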